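The compounds below may be only part of what the source reports. "The series", "measured", "known", "first", "only" and "open" are said of these compounds alone.

The compounds are compared in a functional assay on A-375 cells (Homo sapiens) for antiproliferative activity, read by MTT assay, with a stated time of 72 h; on this read-out higher numbers stand for weaker inhibition and lower numbers for stronger inhibition. In this assay compound 1 `COc1cccc(N2C(=O)COc3ccc(-c4cnc(Cl)c(NS(=O)(=O)c5ccc(F)cc5)c4)cc32)c1` gives only a limit, > 40000 nM. Compound 2 `COc1cccc(N2C(=O)COc3ccc(-c4cnc5ccccc5c4)cc32)c1` gives a measured number, 23600 nM. Compound 3 `COc1cccc(N2C(=O)COc3ccc(-c4cccc(NS(=O)(=O)c5ccc(F)cc5)c4)cc32)c1` also gives only a limit, > 40000 nM. Among the compounds with values here, compound 3 therefore stands with compound 1 at the limit of > 40000 nM in this assay, at which 2 of the 3 values shown sit, and no measured step connects any of these three compounds.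

The next compound is compound 4 `COc1ccc(N2C(=O)COc3ccc(-c4cccc(NS(=O)(=O)c5ccc(F)cc5)c4)cc32)cc1`, which has the same atoms as compound 3, joined differently. The difference is 4-methoxyphenyl in place of 3-methoxyphenyl on an amide-type nitrogen in a ring. In words, a 4-methoxyphenyl stands in place of a 3-methoxyphenyl on an amide-type nitrogen in a ring, while the rest of the structure stays as it is.

Within the data shown here, with no measured step as a guide, no step beyond the usual scatter is expected in this assay, and no direction can be favoured. The expectation rests on compound 3, whose limit is > 40000 nM, and another reading that gives only a limit is thought the likeliest outcome. The expected size of the change is estimated as an at least 1.0-fold lower number from compound 3 to compound 4 (0.02 log units; that floor lies within the scatter). Compound 4 is estimated at 38000 nM, with an expected range from 15000 nM to 70000 nM.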

Compound 4, half-maximal inhibitory concentration: 38500 nM
Compound 4: middle estimate off by 1.0-fold (0.01 log units), on the low side, within the range that was stated.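

In this assay, placing 4-methoxyphenyl in place of 3-methoxyphenyl on the amide-type nitrogen in a ring gives an at least 1.0-fold lower number from compound 3 to compound 4 (0.01 log units; that floor lies within the scatter). Compound 4 gives a measured number, 38500 nM, and among the compounds shown that carry the 4-fluorophenyl sulfonamide, it is the only one with a number rather than a limit. Compound 3 itself gives only a limit, so this step has a floor but no true size, and that limit remains the most common reading among the compounds shown: the limit of > 40000 nM in this assay, at which 2 of the 4 values shown sit.

The compounds shown leave open whether a different group on the amide-type nitrogen in a ring, such as an unsubstituted phenyl, a hydroxyphenyl bearing a free hydroxyl, or a longer chain with a terminal amine, would give a number clearly lower than that of compound 4. Within the data shown here, they also leave open what the group on the other side of the core contributes: compound 2 gives 23600 nM, but no measured step connects it to the compounds that carry the sulfonamide.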